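The source may report more compounds than this note shows. Statements on the series, on what has been measured and on what is new or still open speak of the compounds shown alone.

Values from a functional assay on A549 cells (Homo sapiens) for inhibition, read by MTT assay, with a stated time of 24 h (on this read-out higher numbers stand for weaker inhibition and lower numbers for stronger inhibition), for the measured compounds:

- Compound 1 `C/C=C(\C)C(=O)O[C@@H]1[C@]2(OC(=O)CCCC)C=C3C4=CC(=O)O[C@@H](c5ccoc5)[C@]4(C)CC[C@@H]3[C@@]3(C)[C@H](C[C@]1(C)[C@H]3[C@@H](O)C(=O)OC)O2` gives 9400 nM
- Compound 2 `C/C=C(\C)C(=O)O[C@@H]1[C@]2(OC(=O)C3CC3)C=C3C4=CC(=O)O[C@@H](c5ccoc5)[C@]4(C)CC[C@@H]3[C@@]3(C)[C@H](C[C@]1(C)[C@H]3[C@@H](O)C(=O)OC)O2` gives 11800 nM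

Among the measured compounds shown here, compound 2 cannot be told apart from compound 1, since the only measured step is a 1.3-fold higher number from compound 1 to compound 2 (0.10 log units; within the scatter) and it places cyclopropyl in place of butyl on a carbonyl carbon. Compound 3 `C/C=C(\C)C(=O)O[C@@H]1[C@]2(OC(=O)C3CC3)C=C3C4=CC(=O)O[C@@H](c5ccoc5)[C@]4(C)CC[C@@H]3[C@@]3(C)[C@H](C[C@]1(C)[C@H]3[C@@H](OC(=O)C1CC1)C(=O)OC)O2` differs from compound 2 by cyclopropylcarbonyl in place of hydrogen on an oxygen on a saturated carbon, which turns hydroxy into (cyclopropylcarbonyl)oxy. For the measured compounds named here, no measured compound carries a group on this oxygen, so the one measured step, made at a different place, bears on the change only weakly. It gives no reason to expect a step beyond the scatter in either direction in this assay, although the uncertainty is wide. The expected step is a 1.2-fold lower number from compound 2 to compound 3 (0.07 log units; within the scatter) and remains only an estimate. Compound 3 is estimated at 10000 nM, with an expected range from 4000 nM to 25000 nM in this read-out.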

Compound 3, half-maximal inhibitory concentration: > 100000 nM
Compound 3: a limit, no number; the forecaster's own chance of this, stated with the estimate: 10%; middle value at least 10-fold (1.00 log units) away from the limit.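

Compound 1 and compound 2 both keep the free hydroxy, so only compound 3 shows what a group on this oxygen on a saturated carbon does. In this assay compound 3 gives no number, only a limit: the limit of > 100000 nM in this assay, at which 1 of the 3 values shown sits.

Even so, turning hydroxy into (cyclopropylcarbonyl)oxy gives an at least 8.4-fold higher number from compound 2 to compound 3 (0.92 log units; beyond the scatter), whereas cyclopropyl in place of butyl on a carbonyl carbon gave only a 1.3-fold higher number from compound 1 to compound 2 (0.10 log units; within the scatter), so this oxygen is far less forgiving of change than that carbonyl carbon.

As far as these compounds go, what stays open is whether the step belongs to the cyclopropylcarbonyl group itself or to any group on this oxygen. A smaller acetyl ester or a methyl ether there would separate the two, and a longer chain such as butanoyl would show whether the size of the ester matters.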